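Oxadiazole to methylpyrazole on the cycloheptyl urea core

The source may report more compounds than this note shows. Statements on the series, on what has been measured and on what is new or still open speak of the compounds shown alone.

Compound 1 `Cc1cc(C)c(NC(=O)N(Cc2ccc(-c3nnc(C)o3)cc2)C2CCCCCC2)c(C)c1` holds the second highest of the three numbers in an assay on microsomes from intestine for inhibition of acyl-CoA:cholesterol acyltransferase (Oryctolagus cuniculus) (a higher number here means a weaker inhibitor, a lower number a stronger inhibitor), where compound 1 gives 27 nM. In this assay compound 2 `CN(C)c1ccc(CN(Cc2cccc(-c3cc[nH]n3)c2)C(=O)Nc2c(F)cc(F)cc2F)cc1` gives 12 nM, a lower number beyond the scatter, and compound 3 `CSc1cc(C)nc(SC)c1NC(=O)N(Cc1ccccc1)Cc1cccc(-c2ccn(C)n2)c1` gives 73 nM, a higher number beyond the scatter. Compound 4 `Cc1cc(C)c(NC(=O)N(Cc2ccc(-c3ccn(C)n3)cc2)C2CCCCCC2)c(C)c1` is not yet measured. It differs from compound 1 in one place: 1-methyl-1H-pyrazol-3-yl in place of 5-methyl-1,3,4-oxadiazol-2-yl on an aromatic carbon. Compound 3 carries the same 1-methyl-1H-pyrazol-3-yl on a different core, so its value settles nothing about this step. Among the compounds with values here, no measured pair isolates the change; the expected step of a 1.3-fold higher number from compound 1 to compound 4 (0.11 log units; within the scatter) is none beyond the scatter. For compound 4 the estimate in this assay is 35 nM, with a range from 12 nM to 100 nM.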

Compound 4, half-maximal inhibitory concentration: 44 nM
The estimate for compound 4 lay 1.3-fold (0.10 log units) below the measured number; low and high end bracket the measured number.
By their numbers in this assay, from the lowest: compound 2; then compounds 1, 4 and 3 (each within the scatter of the next, the first and the last beyond it).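

On the shared core, the aromatic carbon para to a large group accepts 1-methyl-1H-pyrazol-3-yl in place of 5-methyl-1,3,4-oxadiazol-2-yl: this assay reads a 1.6-fold higher number from compound 1 to compound 4 (0.21 log units; within the scatter) for this exchange. Within the data shown here, this pair is the first to isolate the change, and it shows that the two five-membered aromatic rings cannot be told apart here. No measurement at hand accounts for the step or links it to any property of either ring.

On these data alone, whether the exchange behaves alike on the cores of compound 2 and compound 3 remains open. Also open, as far as these compounds go, is how a carboxylic acid or a primary amide would read at this position.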